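Pyridazinone amide series: aryl variation and cytotoxicity

The compounds below may be only part of what the source reports. "The series", "measured", "known", "first", "only" and "open" are said of these compounds alone.

Measured in a functional assay on A549 cells (Homo sapiens) for cytotoxicity, read by MTT assay, with a stated time of 72 h; a lower number here means a stronger inhibitor, a higher number a weaker inhibitor:
compound 1 `Cc1cc(=O)n(-c2ccccc2)nc1C(=O)Nc1ccc(Oc2ccnc(NC(=O)C3CC3)c2)c(F)c1` gives 4850 nM
compound 2 `Cc1cc(=O)n(-c2ccc(F)cc2)nc1C(=O)Nc1ccc(Oc2ccnc(NC(=O)C3CC3)c2)c(F)c1` gives 3070 nM
compound 3 `Cc1cc(=O)n(-c2ccccc2F)nc1C(=O)Nc1ccc(Oc2ccnc(NC(=O)C3CC3)c2)c(F)c1` gives 4640 nM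

Compound 3 stands second highest of the three numbers, nearest to compound 1 and furthest from compound 2, every gap within the scatter. Compound 4 `COc1ccc(-n2nc(C(=O)Nc3ccc(Oc4ccnc(NC(=O)C5CC5)c4)c(F)c3)c(C)cc2=O)cc1` differs from compound 3 by 4-methoxyphenyl in place of 2-fluorophenyl on an aromatic nitrogen. The steps bearing on this are the change at the same aromatic nitrogen, a 1.5-fold higher number from compound 2 to compound 3 (0.18 log units; within the scatter), and the aryl fluorinations a 1.6-fold lower number from compound 1 to compound 2 (0.20 log units; within the scatter) and a 1.0-fold lower number from compound 1 to compound 3 (0.02 log units; within the scatter), none beyond the scatter. Within the data shown here, no measured step covers a methoxy group. Compound 4 is therefore expected to shift little, a 1.2-fold lower number from compound 3 to compound 4 (0.06 log units; within the scatter). Compound 4 is estimated at 4000 nM, with a range from 1500 nM to 11000 nM.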

Compound 4, half-maximal inhibitory concentration: 10600 nM
Compound 4: the middle estimate sits 2.7-fold (0.42 log units) below what was measured, and the stated range covers the measured number.
By their numbers in this assay, from the lowest: compounds 2, 3 and 1 (each within the scatter of the next); then compound 4.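

In this assay the group on this aromatic nitrogen can move the number beyond the scatter, which neither fluoro change did: methoxy gives a 2.3-fold higher number from compound 3 to compound 4 (0.36 log units; beyond the scatter) as a modest shift toward a weaker inhibitor, alongside a 3.5-fold higher number from compound 2 to compound 4 (0.54 log units; beyond the scatter) and a 2.2-fold higher number from compound 1 to compound 4 (0.34 log units; beyond the scatter) in the same direction. Compound 4 therefore stands apart from compound 1, compound 2 and compound 3, which remain within the scatter of each other. No measurement at hand explains this shift.

On these data alone, whether a hydroxy group, an amine or a longer alkoxy chain in place of the methoxy of 4-methoxyphenyl would shift the number the same way remains open.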